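A few compounds are considered here, and "the series" means these few. Any claim that something is new, unique, unknown or untested is made for them only; others in the source may bear on it.

Measured so far in a functional assay on SW480 cells (Homo sapiens) for antiproliferative activity, read by MTT assay, with a stated time of 72 h; on this read-out lower numbers stand for stronger inhibition and higher numbers for weaker inhibition:

Compound 1 `O=c1c(Cl)c(CSC(=S)N2CCOCC2)oc2ccccc12`: 1800 nM
Compound 2 `COc1ccc2occ(CSC(=S)N3CCCCC3)c(=O)c2c1`: 6700 nM
Compound 3 `COc1ccc2occ(CSC(=S)N(C(C)C)C(C)C)c(=O)c2c1`: 4800 nM

Among these three, compound 1 gives the lowest number, and its distance to the other two is beyond the usual scatter: compound 3 stands nearest to it and compound 2 furthest. Compound 4 `O=c1c(Cl)c(CSC(=S)N2CCCC2)oc2ccccc12` is compound 1 with one change: pyrrolidin-1-yl in place of morpholin-4-yl on a thiocarbonyl carbon.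

For the measured compounds named here, only one measured step bears on swapping the amine part on the thiocarbonyl carbon. From compound 2 to compound 3, a 1.4-fold lower number from compound 2 to compound 3 (0.14 log units; within the scatter), which is within the scatter. That step sits on a different core, so it is only a rough guide, but it suggests that changing the ring on the thiocarbonyl carbon does little in this assay . For compound 4 a small move is therefore expected, a 1.1-fold lower number from compound 1 to compound 4 (0.05 log units; within the scatter), with no clear direction beyond the scatter. Compound 4 is estimated to give about 1600 nM in this assay , in a range from 600 nM to 4500 nM.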

Compound 4, half-maximal inhibitory concentration: 1400 nM
Compound 4: middle estimate off by 1.1-fold (0.06 log units), on the high side; low and high end bracket the measured number.
By their numbers in this assay, from the lowest: compounds 4 and 1 (each within the scatter of the next); then compounds 3 and 2 (each within the scatter of the next).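

On the core of compound 1, in this assay, the swap of morpholin-4-yl for pyrrolidin-1-yl on a thiocarbonyl carbon gives a 1.3-fold lower number from compound 1 to compound 4 (0.11 log units; within the scatter), so the two compounds cannot be told apart. For the compounds shown here, this is the first direct look at the amine part on this core, and it shows that both the oxygen of morpholin-4-yl, the hydrogen-bond acceptor that pyrrolidin-1-yl lacks, and the six-membered ring can be exchanged with no difference beyond the scatter. No measurement is available to explain this result.

On these data alone, what remains open is whether this tolerance extends to other amine parts on the same core, such as an open-chain diethylamino group or a piperazin-1-yl ring carrying a free amine hydrogen. Either could show whether the thiocarbonyl carbon accepts larger changes as readily.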